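Putting a sulfonyl group on the ring nitrogen

A few compounds are considered here, and "the series" means these few. Any claim that something is new, unique, unknown or untested is made for them only; others in the source may bear on it.

Among the compounds with values here, in a functional assay on HepG2 cells (Homo sapiens) for cytotoxicity, read by MTT assay, with a stated time of 24 h (a higher number here means a weaker inhibitor, a lower number a stronger inhibitor), compound 2 (`O=C1/C(=C/c2cccnc2)CNC/C1=C\c1ccccc1F`) gives 21000 nM and holds the higher of the two numbers so far. Compound 1 (`CN1C/C(=C\c2cccnc2)C(=O)/C(=C/c2cc([N+](=O)[O-])ccc2F)C1`) gives 6630 nM in this assay and so sits lower, by a gap beyond the usual scatter. Compound 3 (`O=C1/C(=C/c2cccnc2)CN(S(=O)(=O)c2ccc(Br)cc2)C/C1=C\c1ccccc1F`) comes from compound 2 by a single change ((4-bromophenyl)sulfonyl in place of hydrogen on an amine nitrogen in a ring) in which (4-bromophenyl)sulfonyl stands in place of hydrogen on an amine nitrogen in a ring. Within the data shown here, no measured pair shows this change alone. Among the measured compounds shown here, the only hint is compound 1 (6630 nM), the one measured compound without hydrogen on that nitrogen, and it differs elsewhere too. The expected move is a 4.2-fold lower number from compound 2 to compound 3 (0.62 log units; beyond the scatter) toward a stronger inhibitor, a step estimated to lie beyond the scatter. For compound 3 the estimate is 5000 nM with an expected range from 1500 nM to 16000 nM in this rough forecast.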

Compound 3, half-maximal inhibitory concentration: 8700 nM
Compound 3: middle estimate off by 1.7-fold (0.24 log units), on the low side; the range from low to high includes it.
By their numbers in this assay, from the lowest: compounds 1 and 3 (each within the scatter of the next); then compound 2.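

Within the data shown here, replacing the hydrogen on the amine nitrogen in the ring of compound 2 with (4-bromophenyl)sulfonyl gives, in this assay, a 2.4-fold lower number from compound 2 to compound 3 (0.38 log units; beyond the scatter), the first reading of this change on its own. The step is modest, but it shows that this nitrogen can carry a much larger group, with 10 heavy atoms and an aromatic ring, and that the number still moves toward a stronger inhibitor. No measurement at hand explains this shift.

The compounds shown leave open which part of the new group goes with the step: the sulfonyl, the aromatic ring or the bromine. From the compounds shown here alone, a methylsulfonyl or an unsubstituted phenylsulfonyl group on the same nitrogen would begin to separate these parts, and whether the shift holds on other cores also remains open.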